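Amide cap change in the pyrazole series: cyclohexenyl for nitrophenyl

The source may hold more compounds than are shown below. What is called first, only, known or untested is meant among the compounds shown, and "the series" means these compounds.

Three compounds of the shared core have numbers in an assay on HEK293 cells for displacement of a labelled ligand from metabotropic glutamate receptor 5 (Rattus norvegicus); a higher number here means a weaker inhibitor, a lower number a stronger inhibitor. Compound 1 `O=C(Nc1cc(-c2ccccc2)nn1-c1ccccc1)c1cccc([N+](=O)[O-])c1` gives 2220 nM in this assay, the second highest of the three numbers. Compound 2 `COc1cccc(-c2cc(NC(=O)c3ccccc3)n(-c3ccccc3)n2)c1` gives 3200 nM in this assay; it and compound 1 differ in more than one place, and their two values lie within the scatter of each other. Among the compounds with values here, compound 3 `O=C(Nc1cc(-c2ccccc2)nn1-c1ccccc1Br)c1cccc([N+](=O)[O-])c1` gives 230 nM in this assay, and the one single-place step known, a 9.7-fold lower number from compound 1 to compound 3 (0.98 log units; beyond the scatter), concerns bromo in place of hydrogen on an aromatic carbon.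

Compound 4 `O=C(Nc1cc(-c2ccccc2)nn1-c1ccccc1)C1=CCCCC1` differs from compound 1 as follows: cyclohex-1-en-1-yl in place of 3-nitrophenyl on a carbonyl carbon. Within the data shown here, no measured step touches the group on the carbonyl carbon; the step from compound 1 to compound 3 sits elsewhere and does not inform this change. The expectation for compound 4 therefore rests on compound 1 alone, with a wide range and no firm direction; a step toward a somewhat higher number, a 1.8-fold higher number from compound 1 to compound 4 (0.26 log units; within the scatter), is expected. Compound 4 is estimated at 4000 nM in this assay, within 900 nM to 20000 nM.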

Compound 4, inhibition constant: 4470 nM
For compound 4 the middle estimate is 1.1-fold (0.05 log units) below the measured one; measured number inside the range.
By their numbers in this assay, from the lowest: compound 3; then compounds 1, 2 and 4 (each within the scatter of the next).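

In this assay the change on the carbonyl carbon gives a 2.0-fold higher number from compound 1 to compound 4 (0.30 log units; within the scatter) and so stays within the scatter. At this place, for this one pair, a non-aromatic carbon ring with 0 hydrogen-bond acceptors therefore holds the number at the level of compound 1, so neither the aromatic ring of 3-nitrophenyl nor its 2 hydrogen-bond acceptors is required here. Nothing measured bears on why the number stays at this level.

Going by these compounds, whether the bromo step seen from compound 1 to compound 3 carries over to a compound with cyclohex-1-en-1-yl on the carbonyl carbon remains open. On these data alone, the response at this place to a saturated cyclohexyl ring, a short alkyl chain, an amine or a carboxylic acid also remains open.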